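A methylphenyl amine in place of a trifluoromethylphenyl amine

The source may hold more compounds than are shown below. What is called first, only, known or untested is meant among the compounds shown, and "the series" means these compounds.

In a functional assay on PC-3 cells (Homo sapiens) for cytotoxicity, read by MTT assay, with a stated time of 72 h (a lower number here means a stronger inhibitor, a higher number a weaker inhibitor), compound 2 `FC(F)(F)c1ccc(CSc2nc(Nc3cccc(C(F)(F)F)c3)c3ccccc3n2)cc1` gives 12900 nM, the highest of the two numbers shown, though this difference lies within the scatter of compound 1 `CCCCCCCCNc1nc(SCc2ccc(C(F)(F)F)cc2)nc2ccccc12`, which gives 10500 nM. Going by the values given here, the only measured step, a 1.2-fold higher number from compound 1 to compound 2 (0.09 log units; within the scatter), exchanged an octyl chain for an aryl group at this nitrogen and stayed within the scatter. Compound 3 `Cc1ccc(Nc2nc(SCc3ccc(C(F)(F)F)cc3)nc3ccccc23)cc1` carries 4-methylphenyl in place of 3-(trifluoromethyl)phenyl on a nitrogen on an aromatic ring. Among the compounds with values here, no measured step covers an exchange of one aryl group for another, so the flat single step is the only guide. The expected step, a 1.1-fold lower number from compound 2 to compound 3 (0.03 log units; within the scatter), lies within the scatter. Compound 3 is thus estimated at 12000 nM, within 4000 nM to 36000 nM.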

Compound 3, half-maximal inhibitory concentration: 21100 nM
For compound 3 the middle estimate is 1.8-fold (0.25 log units) below the measured one, within the range that was stated.
By their numbers in this assay, from the lowest: compounds 1, 2 and 3 (each within the scatter of the next).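

Exchanging one aryl group for another at this nitrogen, 4-methylphenyl for 3-(trifluoromethyl)phenyl, gives in this assay the first aryl-for-aryl step (a 1.6-fold higher number from compound 2 to compound 3 (0.21 log units; within the scatter)). Set against the octyl chain, 4-methylphenyl gives a step that also stays within the scatter (a 2.0-fold higher number from compound 1 to compound 3 (0.30 log units; within the scatter)), so the three groups shown on this nitrogen cannot be told apart in this assay. Nothing measured here explains the result.

Going by these compounds, whether any group on this nitrogen can move the number beyond the scatter remains open. A carboxylic acid or an amine on the ring in place of methyl would test that.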